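A Thioether Swap at the Aryl Ether Position

A few compounds are considered here, and "the series" means these few. Any claim that something is new, unique, unknown or untested is made for them only; others in the source may bear on it.

Compound 1 `CCOC(=O)[C@H](CCC(=O)O)NC(=O)c1ccc(Sc2nc3cc(N)cc(N)c3nc2-c2ccccc2)cc1` gives 12600 nM.
Compound 2 `Nc1cc(N)c2nc(-c3ccccc3)c(Oc3ccc(F)cc3)nc2c1` gives 12300 nM.
Compound 3 `COc1cc(CNc2nc3cc(N)cc(N)c3nc2-c2ccccc2)cc(OC)c1OC` gives 724 nM.

The three measured compounds share one core and differ in the group attached on the aromatic carbon ortho to the phenyl group. In a functional assay on SK-MEL-5 cells (Homo sapiens) for inhibition, read by sulforhodamine B assay, with a stated time of 48 h (a higher number here means a weaker inhibitor of growth, a lower number a stronger inhibitor of growth), compound 2 gives 12300 nM, the second highest of the three numbers. Its nearest neighbour is compound 1, whose value of 12600 nM sits within the scatter of compound 2, so no order between the two can be claimed. Compound 3, with 724 nM, lies well beyond the scatter from compound 2, on the stronger side.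

Compound 4 `COc1ccc(Sc2nc3cc(N)cc(N)c3nc2-c2ccccc2)cc1` has not yet been measured. It differs from compound 2 in one place: (4-methoxyphenyl)sulfanyl in place of 4-fluorophenoxy on an aromatic carbon. Compound 1 also carries a sulfanyl link to an aromatic ring at this position and is no stronger than compound 2, so the change of linker alone gives no reason to expect a large gain. The expected step of a 1.5-fold lower number from compound 2 to compound 4 (0.19 log units; within the scatter) is therefore small, at most a modest lowering, and may fall within the scatter. Compound 4 is estimated at 8000 nM, with a range from 2500 nM to 25000 nM.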

Compound 4, concentration for 50% growth inhibition: 24000 nM
Beside the measured number, compound 4's estimate is 3.0-fold (0.48 log units) below it, and the stated range covers the measured number.
By their numbers in this assay, from the lowest: compound 3; then compounds 2, 1 and 4 (each within the scatter of the next).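

In this assay, among these compounds, the step at this position, a 2.0-fold higher number from compound 2 to compound 4 (0.29 log units; within the scatter), is the first that can be read between two compounds differing in one place, and it leaves compound 2 and compound 4 indistinguishable. Putting (4-methoxyphenyl)sulfanyl in place of 4-fluorophenoxy on this aromatic carbon therefore gives no measurable separation, although the entering group differs in its link atom and in the group carried on its ring, so this single step shows only the two differences taken together. Nothing available here offers a measured reason for this outcome.

The compounds shown leave open how the link atom and the ring substituent each contribute, a question that a pair such as 4-fluorophenylsulfanyl and 4-methoxyphenoxy on the shared core would address. They also leave open how a piperazine or a morpholine at this position would read in this assay, and whether either would stand apart from compound 2 and compound 4 by more than the usual scatter.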